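Trifluoromethyl in Place of Trifluoromethoxy: Compound 4 Expected

The source may hold more compounds than are shown below. What is called first, only, known or untested is meant among the compounds shown, and "the series" means these compounds.

Compound 3 `Cc1c(C(=O)Nc2c(F)cc(-c3cccc(F)c3)cc2F)nc2ccc(OC(F)(F)F)cc2c1O` stands second highest of the three numbers in a functional assay on Hep 3B2 cells (Homo sapiens) for antiproliferative activity, read by MTT assay, with a stated time of 24 h, tested at 33.33 ug/mL (a lower number here means a weaker effect, a higher number a stronger effect of the compound at the concentration tested), where compound 3 gives 41.3%. Its nearest neighbour is compound 1 `Cc1ccc2nc(C(=O)Nc3c(F)cc(-c4cccc(F)c4)cc3F)c(C)c(O)c2c1`, which gives 37.3%, and the step of a number 4 percentage points higher from compound 1 to compound 3 (within the scatter). Compound 2 `CCc1ccc2nc(C(=O)Nc3c(F)cc(-c4cccc(F)c4)cc3F)c(C)c(O)c2c1` gives 56.3%, and the step of a number 15 percentage points lower from compound 2 to compound 3 (beyond the scatter). Compound 4 `Cc1c(C(=O)Nc2c(F)cc(-c3cccc(F)c3)cc2F)nc2ccc(C(F)(F)F)cc2c1O` differs from compound 3 by trifluoromethyl in place of trifluoromethoxy on an aromatic carbon. Among the compounds with values here, no measured step replaces trifluoromethoxy by trifluoromethyl. Within the data shown here, the steps that bear on this position are a number 19 percentage points higher from compound 1 to compound 2 (beyond the scatter) and a number 15 percentage points lower from compound 2 to compound 3 (beyond the scatter), both modest, together with a number 4 percentage points higher from compound 1 to compound 3 (within the scatter). Because a number 4 percentage points higher from compound 1 to compound 3 (within the scatter) stayed within the scatter for a small change at this place, no step beyond the scatter is expected here. Compound 4 is therefore estimated at 42%, between 28% and 58%, an expected step of a number 0.7 percentage points higher from compound 3 to compound 4 (within the scatter).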

Compound 4, a percentage reported as inhibition, at one concentration (the size of the read-out at that concentration, not a potency): 45.2%
For compound 4 the middle estimate is 3.2 percentage points below the measured one, within the range that was stated.
By their numbers in this assay, from the lowest: compounds 1, 3 and 4 (each within the scatter of the next); then compound 2.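

In this assay the exchange of trifluoromethoxy for trifluoromethyl is now read directly, and the step is a number 3.9 percentage points higher from compound 3 to compound 4 (within the scatter), so the two groups cannot be told apart at this aromatic carbon. Trifluoromethyl also stays level with methyl, with a number 7.9 percentage points higher from compound 1 to compound 4 (within the scatter), while ethyl remains the one group that stands apart, with a number 11.1 percentage points lower from compound 2 to compound 4 (beyond the scatter). Nothing given here accounts for these differences. From the compounds shown here alone, whether a longer chain such as propyl would keep the number raised remains open. So does the effect of an amine or a carboxylic acid at this place.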